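The source may hold more compounds than are shown below. What is called first, only, known or untested is meant among the compounds shown, and "the series" means these compounds.

Measured in an ADME assay on HEp-2 cells (Homo sapiens) for cytotoxicity; a higher number here means that more compound is tolerated, a lower number that less compound is tolerated:
- compound 1 `O=c1c(Br)cc2ccccc2n1Cc1nc2ccccc2n1CCCCF`: 26200 nM
- compound 2 `CN1C(=O)N(Cc2nc3ccccc3n2CCCCF)c2ccccc2S1(=O)=O`: 87700 nM
- compound 3 `O=C1N(Cc2nc3ccccc3n2CCCCF)c2ccccc2S(=O)(=O)N1C1CC1`: 111000 nM

All three compounds carry a 4-fluorobutyl chain. Compound 3, at 111000 nM, stands level with compound 2 within the scatter. Compound 1 gives 26200 nM. The number of compound 3 is higher than that of compound 1, and this gap lies beyond the scatter.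

Compound 4 `N#CCCCn1c(CN2C(=O)N(C3CC3)S(=O)(=O)c3ccccc32)nc2ccccc21` keeps the core and the cyclopropyl group of compound 3 and changes only the chain: cyano in place of fluoromethyl on a saturated chain carbon, three bonds along the chain from an aromatic nitrogen. The 4-fluorobutyl chain thus becomes 3-cyanopropyl.

Among the compounds with values here, no measured step touches this chain. Within the data shown here, the only step available is a 1.3-fold higher number from compound 2 to compound 3 (0.10 log units; within the scatter), and it concerns cyclopropyl in place of methyl on an amide-type nitrogen in a ring, so it bears on the new change only indirectly. It shows that one change elsewhere on this core left this assay within the scatter, but the data give no direct guide to swapping the chain end. With nothing pointing either way, no shift beyond the scatter is expected. The estimated step is a 1.1-fold lower number from compound 3 to compound 4 (0.05 log units; within the scatter). For compound 4 the expected value is 100000 nM, with an estimated range from 45000 nM to 220000 nM.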

Compound 4, half-maximal cytotoxic concentration: > 244000 nM
Compound 4 ended at the assay's limit; the forecaster's own chance of this, stated with the estimate: 15%; middle value at least 2.4-fold (0.38 log units) from the limit.
By their numbers in this assay, from the lowest: compound 1; then compounds 2 and 3 (each within the scatter of the next). At a limit, above all of these: compound 4.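

In this assay compound 4 gives > 244000 nM, which is a limit of the assay and not a number. Within the data shown here, with cyano in place of fluoromethyl on a saturated chain carbon, three bonds along the chain from an aromatic nitrogen, the result is an at least 2.1-fold higher number from compound 3 to compound 4 (0.34 log units; beyond the scatter), so this chain end, which no earlier step touched, is a place where a single change moves the number beyond the scatter, whereas the only earlier step on this core, a 1.3-fold higher number from compound 2 to compound 3 (0.10 log units; within the scatter), stayed within it. The printed step gives only the smallest size the change can have, and its full size cannot be read: the limit of > 244000 nM in this assay, at which 1 of the 4 values shown sits.

As far as these compounds go, what remains open is whether this rise belongs to the cyano group itself or would also appear with another chain end, such as an amine or a carboxylic acid, or with a longer chain carrying the same cyano group. From the compounds shown here alone, it is also open whether 3-cyanopropyl in place of 4-fluorobutyl would give a similar rise on the core of compound 2 or on the core of compound 1.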